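The source may report more compounds than this note shows. Statements on the series, on what has been measured and on what is new or still open speak of the compounds shown alone.

Measured so far:
compound 1 `N/C(=N\NC(=S)N1CCCCC1)c1ccccn1` — 27%
compound 2 `N/C(=N\NC(=S)N1CCCC1)c1ccccn1` — 70.9%
compound 3 `Cc1ccnc(/C(N)=N/NC(=S)N2CCCCC2)c1` — 36.5%

All three were run in a functional assay on A-431 cells (Homo sapiens) for cytotoxicity, read by MTT assay, with a stated time of 72 h, tested at 3 uM; a higher number here means more inhibition of growth at the concentration tested, a lower number less inhibition of growth. Compound 4 `Cc1ccnc(/C(N)=N/NC(=S)N2CCCC2)c1` awaits measurement. The core of compound 3 differs from the core of compound 1 by methyl in place of hydrogen on an aromatic carbon; that step, a number 9.5 percentage points higher from compound 1 to compound 3 (within the scatter), stays within the scatter, so compound 1 and compound 3 read as equivalent. The change from compound 3 to compound 4 is pyrrolidin-1-yl in place of piperidin-1-yl on a thiocarbonyl carbon. The same change from compound 1 to compound 2, (pyrrolidin-1-yl in place of piperidin-1-yl on a thiocarbonyl carbon), produced a number 43.9 percentage points higher from compound 1 to compound 2 (beyond the scatter); the place lines of the two changes are identical word for word. For compound 4 the expected step is a number 38.5 percentage points higher from compound 3 to compound 4 (beyond the scatter), resting on the earlier step of a number 43.9 percentage points higher from compound 1 to compound 2 (beyond the scatter) and on the starting value that compound 3 gives, 36.5%. Compound 4 is expected to give 75%, within 52% to 92%.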

Compound 4, percent growth inhibition at one concentration: 63%
Estimate against measurement, compound 4: 12 percentage points above, within the range that was stated.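

In this assay, pyrrolidin-1-yl in place of piperidin-1-yl on a thiocarbonyl carbon keeps its direction on the methyl-bearing core, a number 26.5 percentage points higher from compound 3 to compound 4 (beyond the scatter), but its size does not carry over unchanged: the same change on two cores in this assay, a number 43.9 percentage points higher (beyond the scatter) from compound 1 to compound 2 and a number 26.5 percentage points higher (beyond the scatter) from compound 3 to compound 4, 17.4 percentage points apart, beyond the scatter of two such steps

Methyl in place of hydrogen on an aromatic carbon also stays within the scatter with pyrrolidin-1-yl present, a number 7.9 percentage points lower from compound 2 to compound 4 (within the scatter), yet the two methyl steps still stand apart: the same change on two cores in this assay, a number 9.5 percentage points higher (within the scatter) from compound 1 to compound 3 and a number 7.9 percentage points lower (within the scatter) from compound 2 to compound 4, 17.4 percentage points apart, beyond the scatter of two such steps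

Two cores show that the direction held here, not that it will hold on a further core, and they do not explain the difference in size.

Open, going by these compounds, is whether morpholin-4-yl or an open-chain dimethylamino group on the thiocarbonyl carbon would follow pyrrolidin-1-yl or piperidin-1-yl. Also open, on these data alone, is how a methoxy group would compare with methyl on the aromatic carbon.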